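Trifluoromethyl added to the ethoxyphenyl ring of compound 3

A few compounds are considered here, and "the series" means these few. Any claim that something is new, unique, unknown or untested is made for them only; others in the source may bear on it.

In a functional assay on SiHa cells (Homo sapiens) for antiproliferative activity, read by CCK-8 assay, with a stated time of 72 h (on this read-out lower numbers stand for stronger inhibition and higher numbers for weaker inhibition), compound 3 `CCOc1ccc(-c2cncnc2-c2cc(OC)c(OC)c(OC)c2)cc1` gives 640 nM. Compound 2 `COc1cc(-c2ncncc2-c2ccc(SC)cc2)cc(OC)c1OC` gives 560 nM, and a 1.1-fold higher number from compound 2 to compound 3 (0.06 log units; within the scatter) stays within the scatter, so these two stand together. Compound 1 `COc1ccc(-c2cncnc2-c2cc(OC)c(OC)c(OC)c2)cc1O` gives 2750 nM, the highest of the three numbers.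

Compound 4 `CCOc1ccc(-c2cncnc2-c2cc(OC)c(OC)c(OC)c2)cc1C(F)(F)F` differs from compound 3 by trifluoromethyl in place of hydrogen on an aromatic carbon, ortho to an ethoxy group. Within the data shown here, no measured step adds a group to this ring while leaving the rest unchanged. The nearest evidence is indirect. Replacing 3-hydroxy-4-methoxyphenyl with 4-ethoxyphenyl gave a 4.3-fold lower number from compound 1 to compound 3 (0.63 log units; beyond the scatter), and replacing it with 4-(methylsulfanyl)phenyl gave a 4.9-fold lower number from compound 1 to compound 2 (0.69 log units; beyond the scatter). Both steps are modest and beyond the scatter. On this thin basis, a modest rise of similar or smaller size is expected in this assay. The expected step is a 2.0-fold higher number from compound 3 to compound 4 (0.31 log units; beyond the scatter). For compound 4 the estimated value is 1300 nM, with an expected range from 300 nM to 5000 nM.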

Compound 4, half-maximal inhibitory concentration: 20000 nM
Estimate against measurement, compound 4: 15-fold (1.19 log units) below, outside the stated range (above it).
By their numbers in this assay, from the lowest: compounds 2 and 3 (each within the scatter of the next); then compound 1; then compound 4.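

In this assay, among these compounds, trifluoromethyl in place of hydrogen on the aromatic carbon ortho to an ethoxy group gives a 31-fold higher number from compound 3 to compound 4 (1.49 log units; beyond the scatter), the only large step. The earlier steps shown here exchanged groups on this ring and stayed modest or within the scatter, whereas this one adds a single group to an otherwise unchanged compound and shows that activity in this read-out can fall sharply with a change at this position. Nothing available explains a step of this size.

The compounds shown leave open whether a fluorine atom, a methyl group or an amine on this carbon would give a step of similar size. Also open, going by these compounds, is whether the step depends on the ethoxy group, since trifluoromethyl appears here only alongside it.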